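This account rests on a few compounds, and the source may have more. Where it says the series, first, only, none or still open, it means among the compounds named here.

Measured in an ADME assay on Raji cells (Homo sapiens) for cytotoxicity, read by CellTiter-Glo, with a stated time of 72 h; a lower number here means that less compound is needed, a higher number that more compound is needed for the effect:

compound 1 (`CC1=C2CC(C)(C)/C=C/C/C(C)=C\C3=C[C@H](C)C[C@]3(O2)C1=O`) gives 26000 nM
compound 2 (`CC1=C2CC(C)(C)/C=C/[C@@H](O)/C(C)=C\C3=C[C@H](C)C[C@]3(O2)C1=O`) gives 26000 nM
compound 3 (`CC(=O)O[C@@H]1/C=C/C(C)(C)CC2=C(C)C(=O)[C@]3(C[C@@H](C)C=C3/C=C\1C)O2`) gives 26000 nM

Going by the values given here, compound 1 stands level with compound 2 and compound 3 on these numbers, and no measured compound separates from the others.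

The next compound, compound 4 (`CC1=C2CC(C)(C)/C=C/[C@H](OC(=S)n3ccnc3)/C(C)=C\C3=C[C@H](C)C[C@]3(O2)C1=O`), has not yet been measured. Its change from compound 1 is this: a group of 8 heavy atoms (4 carbon, 2 nitrogen, 1 oxygen, 1 sulfur; one five-membered aromatic ring with 2 hetero atoms) in place of a hydrogen atom, on a saturated ring carbon. The new group sits on a saturated ring carbon.

Among the compounds with values here, three measured steps bear on this change. Hydroxy in place of hydrogen on a saturated ring carbon gives no change at the digits printed from compound 1 to compound 2 (within the scatter). Putting an acetoxy group on such a carbon gives no change at the digits printed from compound 1 to compound 3 (within the scatter). Acetyl in place of hydrogen on the oxygen gives no change at the digits printed from compound 2 to compound 3 (within the scatter). None of these steps has any measurable size. However, no measured compound has a five-membered aromatic ring in the entering group, so the read-across is only partial, and the range is kept wide, mainly toward lower numbers.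

The expected step in this assay is a 1.2-fold lower number from compound 1 to compound 4 (0.07 log units; within the scatter), which means no expected shift beyond the scatter. For compound 4 the estimated value is 22000 nM, with an expected range from 6000 nM to 40000 nM.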

Compound 4, half-maximal effective concentration: 26000 nM
For compound 4 the middle estimate is 1.2-fold (0.07 log units) below the measured one, within the range that was stated.
By their numbers in this assay, from the lowest: compounds 1, 2, 3 and 4 (each within the scatter of the next).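

In this assay, a group of 8 heavy atoms with a five-membered aromatic ring with 2 hetero atoms gives no change at the digits printed from compound 1 to compound 4 (within the scatter). The hydroxy and acetoxy compounds had shown only that small oxygen-linked groups on this saturated ring carbon leave the number where it stands, whereas compound 4 extends that observation to a much larger entering group holding nitrogen and sulfur, so the position, next to the ring atom that bears a methyl group, has so far tolerated every group shown without any separation in this read-out. No measurement shown here gives an explanation for this flat result.

Compound 4 is drawn with the opposite configuration at this carbon from compounds 2 and 3, so the compounds shown do not separate the effect of the configuration from that of the group itself. They also leave open whether an amine or a carboxylic acid on this carbon would move the number, and whether a change elsewhere on the shared core would do so.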